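A few compounds are considered here, and "the series" means these few. Any claim that something is new, unique, unknown or untested is made for them only; others in the source may bear on it.

Measured so far in a functional assay on HepG2 cells (Homo sapiens) for cytotoxicity, with a stated time of 72 h; a lower number here means that less compound is needed, a higher number that more compound is needed for the effect:
- Compound 1 `C=C[C@@](C)(/C=C/c1ccc(O)c(C=O)c1)CCC=C(C)C`: > 52000 nM, a limit
- Compound 2 `C=C[C@@](C)(/C=C/c1ccc(O)c(/C=C/C(=O)OCc2ccccc2)c1)CCC=C(C)C`: > 52000 nM, a limit
- Compound 3 `C=C[C@@](C)(/C=C/c1ccc(O)c(/C=C/C(=O)O)c1)CCC=C(C)C`: > 52000 nM, a limit

Compound 3 stands at > 52000 nM, which is a limit and not a number. The series has so far produced no numerical value, and the three compounds share (the limit of > 52000 nM in this assay, at which 3 of the 3 values shown sit).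

The next compound is compound 4 `C=C[C@@](C)(/C=C/c1ccc(O)c(/C=C/C(N)=O)c1)CCC=C(C)C`, and the change is amino in place of hydroxy on a carbonyl carbon. This places amino in place of hydroxy on a carbonyl carbon, turning 2-carboxyethenyl into 2-carbamoylethenyl.

Among the compounds with values here, two measured steps bear on this change: a step that the two limits leave unreadable from compound 1 to compound 3 and a step that the two limits leave unreadable from compound 2 to compound 3. The second acts on the same carbonyl group, on its oxygen, but neither step has a readable size. Neither therefore gives a measured size to carry over to the new change. The expectation rests on these two steps and on the unchanged shared core, and it points to no step beyond the usual scatter in this assay, in either direction. The expected outcome is a step that the limit leaves unreadable from compound 3 to compound 4, and a further report of only a limit is the most likely result. For compound 4 the estimated value is 70000 nM, with an expected range from 35000 nM to 150000 nM.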

Compound 4, half-maximal effective concentration: > 52000 nM
Compound 4: no number, only a limit (the forecaster's own chance of this, stated with the estimate: 85%); the middle value does not contradict the limit.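

In this assay compound 4 gives > 52000 nM, a limit and not a number. No step between compound 4 and compound 1, compound 2 or compound 3 can be read, and the four compounds share one limit: the limit of > 52000 nM in this assay, at which 4 of the 4 values shown sit.

The compounds shown leave open whether compounds 1, 2, 3 and 4 differ at all in this assay.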